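Trifluoromethyl removal on the benzyl piperazine series

The compounds below may be only part of what the source reports. "The series", "measured", "known", "first", "only" and "open" are said of these compounds alone.

Compound 1 `CC(=O)N1CCC(C(=O)N(CCCN2CCN(Cc3ccc(C(F)(F)F)cc3)CC2)c2ccc(C)c(Cl)c2)CC1` stands highest of the two numbers in an ADME assay (Homo sapiens) for cytotoxicity (a higher number here means that more compound is tolerated, a lower number that less compound is tolerated), with 30500 nM. Compound 2 `CCN(Cc1ccccc1)C(=O)C1CCN(CCCN(C(=O)C2CCN(C(C)=O)CC2)c2ccc(C)c(Cl)c2)CC1` gives 83.9 nM in this assay, a gap beyond the scatter. Compound 3 `CC(=O)N1CCC(C(=O)N(CCCN2CCN(Cc3ccccc3)CC2)c2ccc(C)c(Cl)c2)CC1` differs from compound 1 in one place: hydrogen in place of trifluoromethyl on an aromatic carbon. Within the data shown here, no measured pair shows this change, so the step from compound 1 to compound 3 has no measured precedent. The expectation is a step of a 1.1-fold higher number from compound 1 to compound 3 (0.06 log units; within the scatter) in this assay, none beyond the scatter or slightly upward. Compound 3 is estimated at 35000 nM, with a range from 12000 nM to 100000 nM.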

Compound 3, half-maximal cytotoxic concentration: 101000 nM
For compound 3 the middle estimate is 2.9-fold (0.46 log units) below the measured one; the whole stated range lies below it.
By their numbers in this assay, from the lowest: compound 2; then compound 1; then compound 3.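

Going from 4-(trifluoromethyl)benzyl to benzyl gives a 3.3-fold higher number from compound 1 to compound 3 (0.52 log units; beyond the scatter) in this assay, so more compound is tolerated once the trifluoromethyl leaves this aromatic carbon. Among these compounds, this is the first one-place step, and the only reading of this position so far. Nothing measured here accounts for the step.

From the compounds shown here alone, whether fluorine, chlorine, methoxy or a carboxylic acid on this carbon would stand nearer compound 1 or compound 3 stays open. So does whether a trifluoromethyl on the benzyl group of compound 2 would give a comparable step.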